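The compounds below may be only part of what the source reports. "The series", "measured", "known", "first", "only" and "open" are said of these compounds alone.

Working notes on the series, antiproliferative read-out.

Of the compounds shown here, three of the shared core have numbers so far. Compound 1 `N#Cc1c(-c2ccco2)nc2c(c(-c3ccccc3)nn2-c2ccccc2)c1-c1ccc(O)cc1` gives 23900 nM in a functional assay on CCRF-CEM cells (Homo sapiens) for antiproliferative activity, read by resazurin assay, with a stated time of 72 h; on this read-out higher numbers stand for weaker inhibition and lower numbers for stronger inhibition. Compound 2 `COc1ccc(-c2nc3c(c(-c4ccccc4)nn3-c3ccccc3)c(-c3ccc(O)cc3)c2C#N)cc1` gives 6700 nM in this assay. Compound 3 `COc1cc(-c2c(C#N)c(-c3ccco3)nc3c2c(-c2ccccc2)nn3-c2ccccc2)ccc1O` gives 36500 nM, which is the highest number of the three; it sits within the scatter of compound 1 (a 1.5-fold higher number from compound 1 to compound 3 (0.18 log units; within the scatter)) and beyond the scatter of compound 2.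

Compound 4 `COc1cc(-c2c(C#N)c(-c3ccccc3)nc3c2c(-c2ccccc2)nn3-c2ccccc2)ccc1O` is not yet measured. It differs from compound 3 in one place: phenyl in place of furan-2-yl on an aromatic carbon. The measured step that bears on it is the exchange at the same carbon from compound 1 to compound 2, a 4-methoxyphenyl group in place of furan-2-yl, which gave a 3.6-fold lower number from compound 1 to compound 2 (0.55 log units; beyond the scatter). Phenyl is not 4-methoxyphenyl, so the carry-over is uncertain, but a lower number is the expected direction for compound 4 in this assay. The step expected from compound 3 to compound 4 is a 2.4-fold lower number from compound 3 to compound 4 (0.39 log units; beyond the scatter). Compound 4 is therefore estimated at 15000 nM, with a range from 6000 nM to 40000 nM, pending the measurement.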

Compound 4, half-maximal inhibitory concentration: > 50000 nM
Compound 4: only a limit was reported; the forecaster's own chance of this, stated with the estimate: 5%; middle value at least 3.3-fold (0.52 log units) from the limit.
By their numbers in this assay, from the lowest: compound 2; then compounds 1 and 3 (each within the scatter of the next). At a limit, above all of these: compound 4.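

In this assay, compound 4 is reported only as a limit: the limit of > 50000 nM in this assay, at which 1 of the 4 values shown sits. At the carbon next to the ring nitrogen, the exchange reads as an at least 1.3-fold higher number from compound 3 to compound 4 (0.13 log units; that floor lies within the scatter), so phenyl in place of furan-2-yl gives no lower number here, though that floor alone does not separate the two compounds. The carbon therefore does not answer in one direction to every six-membered aromatic ring replacing furan-2-yl, whereas the earlier exchange gave a 3.6-fold lower number from compound 1 to compound 2 (0.55 log units; beyond the scatter).

The two steps differ both in the entering group and in the group elsewhere on the core, so the compounds shown cannot tell whether the methoxy on the entering 4-methoxyphenyl or the 4-hydroxy-3-methoxyphenyl group sets the contrast. Going by these compounds, how an amine or a carboxylic acid on the ring at this carbon would read also stays open.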